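Azetidine to isopropylamine on the shared core

This account rests on a few compounds, and the source may have more. Where it says the series, first, only, none or still open, it means among the compounds named here.

Of the compounds shown here, three have numbers so far. In a functional assay on HEK293 cells for antagonist activity at transient receptor potential cation channel subfamily V member 1 (Rattus norvegicus), read by calcium flux (a lower number here means a stronger inhibitor, a higher number a weaker inhibitor), compound 1 `Cc1cccc(C)c1Nc1nc2c(Nc3ccc(C(F)(F)F)cc3)ncnc2s1` gives 6 nM. Compound 2 `Cc1nc(Nc2ccc(C(F)(F)F)c(Cl)c2)c2nc(Nc3c(Cl)cccc3Cl)sc2n1` gives 2 nM in this assay. Compound 3 `FC(F)(F)c1ccc(Nc2nc(N3CCC3)nc3sc(Nc4c(Cl)cccc4Cl)nc23)cc1` gives 25 nM in this assay, the highest of the three numbers; the gap to compound 1 and the larger gap to compound 2 both lie beyond the scatter of repeated measurements, so compound 3 is the weakest inhibitor among the three measured.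

Compound 4 `CC(C)Nc1nc(Nc2ccc(C(F)(F)F)cc2)c2nc(Nc3c(Cl)cccc3Cl)sc2n1` is not yet measured. It differs from compound 3 in one place: isopropylamino in place of azetidin-1-yl on an aromatic carbon. The position is the one between two ring nitrogen atoms, meta to the (4-(trifluoromethyl)phenyl)amino group. Among the compounds with values here, no measured pair shows this change, and compounds 1 and 2 carry other groups there on differently substituted cores, so no step size can be read off directly. The expected step from compound 3 to compound 4 in this assay is a 1.7-fold lower number from compound 3 to compound 4 (0.22 log units; within the scatter), a modest move toward a lower number, not clearly beyond the scatter. Compound 4 is therefore expected to give about 15 nM in this assay, within a range from 4 nM to 60 nM.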

Compound 4, half-maximal inhibitory concentration: 9 nM
Compound 4: middle estimate off by 1.7-fold (0.22 log units), on the high side; measured number inside the range.
By their numbers in this assay, from the lowest: compound 2; then compounds 1 and 4 (each within the scatter of the next); then compound 3.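

In this assay, the position between two ring nitrogen atoms now has its first one-place comparison, and it is not indifferent to the group it carries: a 2.8-fold lower number from compound 3 to compound 4 (0.44 log units; beyond the scatter). The step is modest, but it shows that isopropylamino is tolerated here and gives the lower number of the pair. The change replaces a four-membered non-aromatic ring with an open group and also brings in a hydrogen-bond donor, and no information on hand explains the step.

This single pair cannot separate the loss of the ring from the gain of the donor. A dimethylamino group, open like isopropylamino but without the amine hydrogen, would speak to that, and a cyclopropylamino group would test a small ring that keeps the hydrogen.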